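The source may report more compounds than this note shows. Statements on the series, on what has been measured and on what is new or still open speak of the compounds shown alone.

Compound 2 `C=CC(=O)Nc1cccc(NC(=O)CSc2nc(Nc3cccc(C)c3)c3ccccc3n2)c1` carries a 3-methylphenyl group on the shared core, and in a functional assay on MDA-MB-231 cells (Homo sapiens) for inhibition, read by MTT assay, with a stated time of 72 h (a lower number here means a stronger inhibitor, a higher number a weaker inhibitor), compound 2 gives 16800 nM. Among the two compounds measured so far it shows the highest number, but its nearest neighbour, compound 1 `C=CC(=O)Nc1cccc(NC(=O)CSc2nc(Nc3ccccc3)c3ccccc3n2)c1`, with 10200 nM in this assay, lies within the scatter of it, so the two cannot be told apart. Going by the values given here, the only measured step, a 1.6-fold higher number from compound 1 to compound 2 (0.22 log units; within the scatter), is a methyl in place of hydrogen on an aromatic carbon, and it stays within the scatter.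

Compound 3 `C=CC(=O)Nc1cccc(NC(=O)CSc2nc(Nc3ccc(F)cc3)c3ccccc3n2)c1` arises from compound 2 through (4-fluorophenyl in place of 3-methylphenyl on a nitrogen on an aromatic ring). This change is not the same as the measured one, since a 3-methylphenyl leaves and a 4-fluorophenyl enters, but the measured step between compound 1 and compound 2 suggests that a small change on this phenyl ring moves the number little. For compound 3 in this assay the step of a 1.4-fold lower number from compound 2 to compound 3 (0.15 log units; within the scatter) is therefore expected to be small, without a clear direction beyond the scatter. The value of compound 3 is estimated at 12000 nM, within a range from 5000 nM to 30000 nM.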

Compound 3, half-maximal inhibitory concentration: 9490 nM
Beside the measured number, compound 3's estimate is 1.3-fold (0.10 log units) above it; the range from low to high includes it.
By their numbers in this assay, from the lowest: compounds 3, 1 and 2 (each within the scatter of the next).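

In this assay, the group on this nitrogen now differs in two further ways, and both steps stay within the scatter: the exchange of 3-methylphenyl for 4-fluorophenyl gives a 1.8-fold lower number from compound 2 to compound 3 (0.25 log units; within the scatter), and adding a fluoro to the phenyl ring of compound 1 gives a 1.1-fold lower number from compound 1 to compound 3 (0.03 log units; within the scatter). Where the earlier pair showed only that a methyl left the number within the scatter, a fluoro now does the same, and the exchange of one substituted phenyl group for another does so as well, so compound 1, compound 2 and compound 3 cannot be told apart and no preference among these three groups can be read from them. No supporting data are available to explain this result.

On these data alone, what stays open is whether any group on this nitrogen can move the number beyond the scatter, since all three groups compared here are small phenyl groups of closely similar size. A dimethylamino group or a carboxylic acid on the phenyl ring, or a longer chain such as a benzyl or phenethyl group in place of the phenyl group, might answer that, and the compounds shown give no indication in either direction.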